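Swapping chloro for hydrogen on compound 3

The source may hold more compounds than are shown below. What is called first, only, known or untested is meant among the compounds shown, and "the series" means these compounds.

Measured in a functional assay on A549 cells (Homo sapiens) for antiproliferative activity, read by MTT assay, with a stated time of 72 h; a higher number here means a weaker inhibitor, a lower number a stronger inhibitor:
Compound 1 `COc1cc(-c2ncnn2-c2ccc(Cl)cc2Cl)cc(OC)c1OC`: > 10000 nM, a limit
Compound 2 `COc1cc(-c2ncnn2-c2ccc(F)cc2)cc(OC)c1OC`: > 10000 nM, a limit
Compound 3 `COc1cc(-c2ncnn2-c2ccc(Cl)cc2)cc(OC)c1OC`: > 10000 nM, a limit

Compound 3 has no exact number: its > 10000 nM is a limit of the assay. It shares this position with the other two compounds, as the record shows: the limit of > 10000 nM in this assay, at which 3 of the 3 values shown sit.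

Compound 4 `COc1cc(-c2ncnn2-c2ccccc2)cc(OC)c1OC` differs from compound 3 in one place: hydrogen in place of chloro on an aromatic carbon. Hydrogen takes the place of chloro on an aromatic carbon, para to a large group, so 4-chlorophenyl becomes phenyl.

The closest measured change is the same swap of chloro for hydrogen, a step that the two limits leave unreadable from compound 1 to compound 3. The other two changes are a step that the two limits leave unreadable from compound 2 to compound 3 and a step that the two limits leave unreadable from compound 1 to compound 2. None of these gives a size, so they offer no sign of a gain, and no shift beyond the scatter is expected in this assay.

The estimated change is a step that the limit leaves unreadable from compound 3 to compound 4. The estimate for compound 4 is 14000 nM, with an expected range from 6000 nM to 40000 nM.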

Compound 4, half-maximal inhibitory concentration: > 10000 nM
Compound 4 was reported as a limit; the forecaster's own chance of this, stated with the estimate: 85%; the middle value is on the limit's open side.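

In this assay compound 4 gives > 10000 nM, which is a limit and not a number. No step from compound 1, compound 2 or compound 3 to compound 4 can be read, as all four sit together: the limit of > 10000 nM in this assay, at which 4 of the 4 values shown sit.

Left open is how strongly any of these compounds acts on the cells, and whether any of the changes shown alters that at all.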